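Exchanging the Acid-Bearing Ring at the Linker End

This account rests on a few compounds, and the source may have more. Where it says the series, first, only, none or still open, it means among the compounds named here.

Of the compounds shown here, three built on one shared core have been measured in an ADME assay (liver) for metabolic stability, with Liver microsome (Rattus norvegicus) as the target, read by LC-MS, using microsomes and NADPH, with stated times of 5 min and 60 min, tested at 4 uM; on this read-out lower numbers stand for a less stable compound and higher numbers for a more stable compound. Compound 1 `Cc1c(OCCCCOc2ccc(C(=O)O)cc2Cl)ccc(C(=O)CC2CCCC2)c1O` gives 21%. Compound 2 `COc1ccc(C(=O)O)cc1OCCCCOc1ccc(C(=O)CC(C)C)c(O)c1C` gives 5% in this assay. Compound 3 `COc1ccc(C(=O)O)cc1OCCCCOc1ccc(C(=O)CC2CCCC2)c(O)c1C` gives 14% in this assay, which places it second highest of the three numbers, but neither neighbour is clearly apart from it: there is a number 7 percentage points lower from compound 1 to compound 3 (within the scatter) and a number 9 percentage points higher from compound 2 to compound 3 (within the scatter).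

Compound 4 `Cc1cc(C(=O)O)ccc1OCCCCOc1ccc(C(=O)CC2CCCC2)c(O)c1C` differs from compound 3 at one end of the molecule only: 4-carboxy-2-methylphenyl in place of 5-carboxy-2-methoxyphenyl on an oxygen on a saturated carbon. Going by the values given here, only one measured step touches this end, namely the move from compound 1 to compound 3, in which a 5-carboxy-2-methoxyphenyl replaced a 4-carboxy-2-chlorophenyl and gave a number 7 percentage points lower from compound 1 to compound 3 (within the scatter). Compound 4 returns to a ring of the 4-carboxy type, carrying a methyl where compound 1 carries chlorine. Among the compounds with values here, since the one comparable exchange stayed within the scatter, no step beyond the scatter is expected here either in this assay; the change estimated is a number 4 percentage points higher from compound 3 to compound 4 (within the scatter). For compound 4 a value of about 18% is expected, most likely falling between 6% and 34%.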

Compound 4, percent of the compound remaining: 59%
Estimate against measurement, compound 4: 41 percentage points below; measured number above the stated range.
By their numbers in this assay, from the lowest: compounds 2, 3 and 1 (each within the scatter of the next, the first and the last beyond it); then compound 4.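

Going by these compounds alone, the acid-bearing end of the molecule turns out to matter a great deal in this assay, although the only earlier exchange there, a number 7 percentage points lower from compound 1 to compound 3 (within the scatter), gave no reading beyond the scatter. With 4-carboxy-2-methylphenyl in place of 5-carboxy-2-methoxyphenyl on the oxygen of the saturated chain, the result is a number 45 percentage points higher from compound 3 to compound 4 (beyond the scatter), and the same compound also stands clear of its chlorine-bearing neighbour, with methyl in place of chloro on an aromatic carbon giving a number 38 percentage points higher from compound 1 to compound 4 (beyond the scatter), so this single swap of one small group on the ring is enough to change the read-out strongly, and the 4-carboxy ring alone does not account for the high number. Nothing available here explains why this one exchange has so large an effect on the percent remaining.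

The compounds shown leave open whether a group such as ethyl, fluoro or trifluoromethyl in the place of that methyl would give a similarly high number. They also leave open whether the 4-carboxy-2-methylphenyl end would give a comparable step with isopropyl in place of cyclopentyl at the other end of the molecule.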